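Chlorophenyl urea swap on two thienopyrimidine cores

The source may report more compounds than this note shows. Statements on the series, on what has been measured and on what is new or still open speak of the compounds shown alone.

Of the compounds shown here, three have been measured in a functional assay on HT-29 cells (Homo sapiens) for cytotoxicity, read by MTT assay, with a stated time of 72 h; a lower number here means a stronger inhibitor, a higher number a weaker inhibitor. Compound 1 `CN(C)CCNc1nc(-c2ccc(NC(=O)Nc3ccc(Cl)cc3)cc2)nc2ccsc12` gives 95 nM. Compound 2 `CN(C)CCNc1nc(-c2ccc(NC(=O)Nc3ccc(Cl)cc3)cc2)nc2c(Cl)c(Cl)sc12` carries the second core, and in this assay compound 2 gives 460 nM. The difference between the two cores is not broken down here. Compound 3 `CN(C)CCNc1nc(-c2ccc(NC(=O)Nc3ccccc3Cl)cc2)nc2ccsc12` keeps the core of compound 1 and differs from it by 2-chlorophenyl in place of 4-chlorophenyl on an amide-type nitrogen; in this assay compound 3 gives 310 nM, so the change brought a 3.3-fold higher number from compound 1 to compound 3 (0.51 log units; beyond the scatter). The values of compound 2 and compound 3 lie within the scatter of each other, so no order between them is claimed.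

Compound 4 `CN(C)CCNc1nc(-c2ccc(NC(=O)Nc3ccccc3Cl)cc2)nc2c(Cl)c(Cl)sc12` has not yet been measured in this assay. It differs from compound 2 by 2-chlorophenyl in place of 4-chlorophenyl on an amide-type nitrogen, and the place is the same in both pairs, so this is the same change that was made from compound 1 to compound 3, now on the core of compound 2. Because a 3.3-fold higher number from compound 1 to compound 3 (0.51 log units; beyond the scatter) was measured on the first core, the step from compound 2 to compound 4 is expected to be of similar size, a 3.3-fold higher number from compound 2 to compound 4 (0.51 log units; beyond the scatter), resting only on that single earlier example. Compound 4 is therefore estimated to give 1500 nM in this assay, with an expected range from 700 nM to 3500 nM.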

Compound 4, half-maximal inhibitory concentration: 570 nM
The estimate for compound 4 lay 2.6-fold (0.42 log units) above the measured number, and the stated range ends above it.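

Among these compounds, on the core of compound 2, putting 2-chlorophenyl in place of 4-chlorophenyl on the amide-type nitrogen gives in this assay a 1.2-fold higher number from compound 2 to compound 4 (0.09 log units; within the scatter), so on this core the change produces no step that stands clear of the scatter. Set beside the step on the core of compound 1, this result does not establish a difference between the two cores, since the two steps lie no further apart than two such steps can scatter: the same change on two cores in this assay, a 3.3-fold higher number (0.51 log units; beyond the scatter) from compound 1 to compound 3 and a 1.2-fold higher number (0.09 log units; within the scatter) from compound 2 to compound 4, 2.6-fold (0.42 log units) apart, within the scatter of two such steps. The series therefore does not show that the change carries over at full size, nor that the core alters its effect; with one pair on each of two cores, the step beyond the scatter on one core and the step within it on the other remain compatible with a single underlying effect or with a real dependence on the core.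

On these data alone, whether the two cores respond alike to other changes at this place stays open, for example to an unsubstituted phenyl, a pyridyl or a cyclohexyl on the same amide-type nitrogen. Also open, as far as these compounds go, is how the two cores compare when the dimethylamino group at the end of the side chain gives way to a morpholine or a piperazine, or when that chain is made longer.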